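A few compounds are considered here, and "the series" means these few. Any claim that something is new, unique, unknown or untested is made for them only; others in the source may bear on it.

Compound 1 `O=C(CCCCCCc1ccccc1)c1nnn[nH]1`: in an assay on HEK-293T cells for inhibition of diacylglycerol lipase-alpha (Homo sapiens), read by colorimetric assay (a lower number here means a stronger inhibitor, a higher number a weaker inhibitor), compound 1 gives > 10000 nM; > 10000 nM (2 entries), which is a limit of the assay.
Compound 2 `CSc1coc(C(=O)CCCCCCc2ccccc2)n1`: in this assay compound 2 gives > 10000 nM, again a limit rather than a number.

Compound 2 therefore stands at the limit of > 10000 nM in this assay, at which 1 of the 2 values shown sits, with no single value to anchor it. Compound 3 `O=C(CCCCCCc1ccccc1)c1ncc(Cl)o1` carries the change (5-chloro-1,3-oxazol-2-yl in place of 4-(methylsulfanyl)-1,3-oxazol-2-yl on a carbonyl carbon). Going by the values given here, no measured step between compounds is available for comparison, so the expected step of an at least 1.2-fold lower number from compound 2 to compound 3 (0.09 log units; that floor lies within the scatter) is taken as small, within the scatter or at most a modest gain, with a fair chance that only a limit is reported again. Compound 3 is expected near 8000 nM, within 1000 nM to 30000 nM.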

Compound 3, half-maximal inhibitory concentration: > 10000 nM
Compound 3: a limit, no number; the forecaster's own chance of this, stated with the estimate: 55%; middle value at least 1.2-fold (0.09 log units) away from the limit.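

No step can be read between compound 2 and compound 3: each gives only a limit in this assay. Still open is whether 5-chloro-1,3-oxazol-2-yl and 4-(methylsulfanyl)-1,3-oxazol-2-yl differ at all, and how strongly any compound shown inhibits.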